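Sulfonamide aryl swaps on a shared core: weak growth inhibition

The source may report more compounds than this note shows. Statements on the series, on what has been measured and on what is new or still open speak of the compounds shown alone.

In a functional assay on cells (leukaemia cell line, Homo sapiens) for inhibition, read by sulforhodamine B assay, with a stated time of 48 h (on this read-out lower numbers stand for stronger inhibition of growth and higher numbers for weaker inhibition of growth), the three measured compounds gave these numbers:
compound 1 `O=S(=O)(Nc1ccccc1Cl)c1ccc(-c2cnc(C3CC3)o2)cc1`: 49700 nM
compound 2 `O=S(=O)(Nc1ccc(F)cc1F)c1ccc(-c2cnc(C3CC3)o2)cc1`: 66100 nM
compound 3 `O=S(=O)(Nc1cc(F)cc(F)c1)c1ccc(-c2cnc(C3CC3)o2)cc1`: 80000 nM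

Compound 1 has the lowest number of the three, but its steps to the others are small: a 1.3-fold higher number from compound 1 to compound 2 (0.12 log units; within the scatter) and a 1.6-fold higher number from compound 1 to compound 3 (0.21 log units; within the scatter), both within the scatter, as is a 1.2-fold higher number from compound 2 to compound 3 (0.08 log units; within the scatter). Compound 4 `COc1cc(NS(=O)(=O)c2ccc(-c3cnc(C4CC4)o3)cc2)ccc1F` is not yet measured; it differs from compound 1 in one place: 4-fluoro-3-methoxyphenyl in place of 2-chlorophenyl on a sulfonamide nitrogen. The two measured steps from compound 1 each swapped the aryl group on the sulfonamide nitrogen and moved the number only within the scatter, so the same is expected here, with no direction beyond the scatter: a 1.2-fold higher number from compound 1 to compound 4 (0.08 log units; within the scatter). Compound 4 is therefore estimated at 60000 nM, within 30000 nM to 120000 nM.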

Compound 4, concentration for total growth inhibition: 75700 nM
Compound 4: the middle estimate sits 1.3-fold (0.10 log units) below what was measured; the measured number falls inside the stated range.
By their numbers in this assay, from the lowest: compounds 1, 2, 4 and 3 (each within the scatter of the next).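

In this assay, going by these compounds alone, the 4-fluoro-3-methoxyphenyl group is the only aryl group here that brings an oxygen and a hydrogen-bond acceptor to the sulfonamide nitrogen, yet a 1.5-fold higher number from compound 1 to compound 4 (0.18 log units; within the scatter) and a 1.1-fold higher number from compound 2 to compound 4 (0.06 log units; within the scatter) and a 1.1-fold lower number from compound 3 to compound 4 (0.02 log units; within the scatter) all lie within the scatter. Adding these atoms therefore leaves all four compounds indistinguishable at this position. Nothing available explains this flat response. Going by these compounds, whether an amine or a carboxylic acid on this aryl ring, or a longer chain in its place, would move the number beyond the scatter stays open.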